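Methyl position swap on a shared diketopiperazine-type scaffold

A few compounds are considered here, and "the series" means these few. Any claim that something is new, unique, unknown or untested is made for them only; others in the source may bear on it.

Measured compounds:
Compound 1, `C=CCn1c(=O)/c(=C\c2ccccc2Cl)[nH]c(=O)/c1=C\c1ccccc1OC`, gives 4400 nM in a functional assay on MOLT-4 cells (Homo sapiens) for cytotoxicity, read by CCK-8 assay, with a stated time of 72 h; on this read-out higher numbers stand for weaker inhibition and lower numbers for stronger inhibition.
Compound 2, `C=CCn1c(=O)/c(=C\c2ccc(F)c(Br)c2)[nH]c(=O)/c1=C\c1ccccc1OC`, is reported as "not active" (no number reported) in this assay.
Compound 3, `C=CCn1c(=O)/c(=C\c2ccc(C)cc2)[nH]c(=O)/c1=C\c1ccccc1OC`, is reported as "not active" (no number reported) in this assay.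

Compound 3 stands without a single number in this assay: it is recorded only as inactive, and compound 2 is the one further entry of that kind. Among the measured compounds shown here, only compound 1 gives a numerical result among the three, at 4400 nM, and no direct single-point step between measured compounds is available.

Compound 4, `C=CCn1c(=O)/c(=C\c2cccc(C)c2)[nH]c(=O)/c1=C\c1ccccc1OC`, has not yet been tested. It differs from compound 3 by 3-methylphenyl in place of 4-methylphenyl on a double-bonded chain carbon bound to an aromatic carbon. For the measured compounds named here, since no step between measured compounds is given, no size of effect can be taken from the data; the expectation is that the step from compound 3 to compound 4 stays within the scatter of this assay, with a fair chance that compound 4 is again reported without a number.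

Compound 4 is expected to give about 20000 nM in this assay, with a range from 4000 nM to 100000 nM.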

Compound 4, half-maximal inhibitory concentration: 16000 nM
For compound 4 the middle estimate is 1.3-fold (0.10 log units) above the measured one; the measured number falls inside the stated range.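

With 3-methylphenyl in place of 4-methylphenyl on a double-bonded chain carbon bound to an aromatic carbon, this assay gives a number where compound 3 has only the record "not active", so this methyl swap separates two compounds made of the same atoms. The size of that change cannot be read, as compound 3 has no number. Replacing 2-chlorophenyl with 3-methylphenyl gives a 3.6-fold higher number from compound 1 to compound 4 (0.56 log units; beyond the scatter), so this second methyl-bearing group keeps a measurable result but does not match the 2-chlorophenyl group of compound 1, and nothing available here explains either difference.

The compounds shown leave open how much of that step belongs to the change from chlorine to methyl and how much to where the group sits on the ring. They also leave open how an unsubstituted phenyl, or a phenyl carrying an amine or a carboxylic acid, would read on this carbon.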